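Shifting a benzamide substituent in a tetrazole series

This account rests on a few compounds, and the source may have more. Where it says the series, first, only, none or still open, it means among the compounds named here.

Measured compounds:
compound 1 `CCCCCCCCCCC(C)(C)NC(=O)c1c(OC)cc(OC)cc1OC`, > 10000 nM
compound 2 `CCCCCCCCCCCCn1nnc(C(NC(=O)c2ccc(Cl)cc2)c2ccccc2)n1`, 440 nM
compound 3 `CCCCCCCCCCCCn1nnc(C(NC(=O)c2cccc(Cl)c2)c2ccccc2)n1`, 250 nM

In an assay on microsomes from liver for inhibition of sterol O-acyltransferase 1 (Rattus norvegicus) (a higher number here means a weaker inhibitor, a lower number a stronger inhibitor), compound 1 gives only a limit of the assay, > 10000 nM. Compound 3 has the lowest number of the two measured values shown, with compound 2 nearest to it; the move from 4-chlorophenyl to 3-chlorophenyl gave a 1.8-fold lower number from compound 2 to compound 3 (0.25 log units; within the scatter). Compound 4 `CCCCCCCCCCCCn1nnc(C(NC(=O)c2ccccc2C(F)(F)F)c2ccccc2)n1` carries the change (2-(trifluoromethyl)phenyl in place of 3-chlorophenyl on a carbonyl carbon). Among the measured compounds shown here, only the step between compound 2 and compound 3 bears on it, and that step stayed within the scatter, so no step beyond the scatter is expected in this assay for compound 4; the estimate is a 1.4-fold higher number from compound 3 to compound 4 (0.15 log units; within the scatter). For compound 4 the expected value is 350 nM, between 120 nM and 1200 nM.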

Compound 4, half-maximal inhibitory concentration: 120 nM
For compound 4 the middle estimate is 2.9-fold (0.46 log units) above the measured one; measured number inside the range.
By their numbers in this assay, from the lowest: compound 4; then compounds 3 and 2 (each within the scatter of the next). At a limit, above all of these: compound 1.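

In this assay, the group on the carbonyl carbon now makes a difference beyond the scatter: 2-(trifluoromethyl)phenyl gives a 2.1-fold lower number from compound 3 to compound 4 (0.32 log units; beyond the scatter), and a 3.7-fold lower number from compound 2 to compound 4 (0.56 log units; beyond the scatter). Among the compounds shown here, the earlier swap between the two chlorophenyl groups had stayed within the scatter, so this is the first sign, though modest, that this place responds to the group it carries. Nothing measured here accounts for the gain. Chlorine and trifluoromethyl changed together with their place on the ring, so the compounds shown do not separate those two changes. From the compounds shown here alone, how a ring bearing an amine or a carboxylic acid would read also remains open.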